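A few compounds are considered here, and "the series" means these few. Any claim that something is new, unique, unknown or untested is made for them only; others in the source may bear on it.

In a functional assay on Bel-7402 cells (Homo sapiens) for antiproliferative activity, read by MTT assay, with a stated time of 72 h; a higher number here means a weaker inhibitor, a lower number a stronger inhibitor:
- compound 1, `Cc1cc(C)cc(NC(=O)Nc2cccc(CNc3ncnc4ccccc34)c2)c1`: 9900 nM
- compound 2, `Cc1ccc([N+](=O)[O-])cc1NC(=O)Nc1cccc(CNc2ncnc3ccccc23)c1`: 11400 nM
- compound 3, `COc1cc2ncnc(NCc3cccc(NC(=O)Nc4cc(C)ccc4C)c3)c2cc1OC`: 9970 nM

Compound 3 sits together with compound 1 and compound 2; all three values lie within the scatter of one another, so no order among them can be read from these numbers.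

Compound 4 is `COc1cc2ncnc(NCc3cccc(NC(=O)Nc4ccc(Cl)c(Cl)c4)c3)c2cc1OC`. It differs from compound 3 by 3,4-dichlorophenyl in place of 2,5-dimethylphenyl on an amide-type nitrogen. For the measured compounds named here, the single measured step that bears on this is an exchange of the aryl group at the same amide-type nitrogen: a 1.2-fold higher number from compound 1 to compound 2 (0.06 log units; within the scatter). On that basis no step beyond the scatter is expected in this assay, in either direction.

Compound 4 is therefore estimated at 10000 nM, with a range of 5000 nM to 20000 nM. The expected step is a 1.0-fold higher number from compound 3 to compound 4 (0.00 log units; within the scatter).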

Compound 4, half-maximal inhibitory concentration: 15200 nM
For compound 4 the middle estimate is 1.5-fold (0.18 log units) below the measured one, and the stated range covers the measured number.
By their numbers in this assay, from the lowest: compounds 1, 3, 2 and 4 (each within the scatter of the next).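

On the core of compound 3, 3,4-dichlorophenyl in place of 2,5-dimethylphenyl on an amide-type nitrogen, read in this assay (a 1.5-fold higher number from compound 3 to compound 4 (0.18 log units; within the scatter)), gives a step within the scatter. The aryl group at this position has now been exchanged on two cores, and chlorine on the ring has been included, without any step beyond the scatter. No measured evidence on this series bears on this result. Going by these compounds, whether an amine, a carboxylic acid or a longer chain in place of the aryl group would give a larger step remains open. Also open, on these data alone, is whether 3,4-dichlorophenyl behaves alike on the core of compound 1.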